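From Phenyl to Methyl at the Chain End

The source may report more compounds than this note shows. Statements on the series, on what has been measured and on what is new or still open speak of the compounds shown alone.

Among the measured compounds shown here, compound 2 `CN1CCC(c2cc(-c3cn(C(=O)NCCCCc4ccccc4)c(=O)o3)ccc2F)CC1` gives 341 nM in an assay on isolated protein for inhibition of acid ceramidase (Homo sapiens), read by LC-MS, with a stated time of 1 h (a higher number here means a weaker inhibitor, a lower number a stronger inhibitor), the higher of the two numbers measured so far; compound 1 `CN1CCC(c2cccc(-c3cn(C(=O)NCCCCc4ccccc4)c(=O)o3)c2)CC1` gives 153 nM, and the step of a 2.2-fold higher number from compound 1 to compound 2 (0.35 log units; beyond the scatter) corresponds to a fluoro in place of hydrogen on an aromatic carbon. Compound 3 `CCCCCNC(=O)n1cc(-c2ccc(F)c(C3CCN(C)CC3)c2)oc1=O` differs from compound 2 by methyl in place of phenyl on a saturated chain carbon, four bonds along the chain from an amide-type nitrogen. For the measured compounds named here, no measured step touches this part of the molecule, so the one known step gives no guide to the size or direction of the change. Compound 3 is therefore expected to land near 600 nM, within 150 nM to 2500 nM, an expected step of a 1.8-fold higher number from compound 2 to compound 3 (0.25 log units; within the scatter).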

Compound 3, half-maximal inhibitory concentration: 1920 nM
The estimate for compound 3 lay 3.2-fold (0.51 log units) below the measured number; low and high end bracket the measured number.
By their numbers in this assay, from the lowest: compound 1; then compound 2; then compound 3.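

In this assay, the step of a 5.6-fold higher number from compound 2 to compound 3 (0.75 log units; beyond the scatter) shows that this position is not indifferent: methyl in place of phenyl, four bonds along the chain from an amide-type nitrogen, gives a change beyond the scatter. Compounds 1 and 2 both carry the phenyl, so they could not show this. Nothing measured here explains the change.

The compounds shown leave open whether a cyclohexyl ring or a pyridine ring at the chain end would match the phenyl. They also leave open how a longer alkyl chain would compare with compound 3.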